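The compounds below may be only part of what the source reports. "The series", "measured", "known", "first", "only" and "open" are said of these compounds alone.

Of the compounds shown here, three sharing one core have been tested so far. Compound 1 `Cc1ccc2[nH]c(-c3cn(-c4ccccc4)nc3-c3ccccc3)nc2c1` gives 5940 nM in a functional assay on MCF7 cells (Homo sapiens) for antiproliferative activity, read by MTT assay, with a stated time of 48 h; on this read-out lower numbers stand for stronger inhibition and higher numbers for weaker inhibition. Compound 2 `FC(F)(F)c1ccc2[nH]c(-c3cn(-c4ccccc4)nc3-c3ccccc3)nc2c1`, which carries the change (trifluoromethyl in place of methyl on an aromatic carbon), gives 2660 nM in this assay, a step of a 2.2-fold lower number from compound 1 to compound 2 (0.35 log units; beyond the scatter). Compound 3 `Cc1ccc2[nH]c(-c3cn(-c4ccccc4)nc3-c3ccc(F)cc3)nc2c1` gives 1120 nM in this assay, and it differs from compound 1 by fluoro in place of hydrogen on an aromatic carbon, a step of a 5.3-fold lower number from compound 1 to compound 3 (0.72 log units; beyond the scatter).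

Compound 4 `Fc1ccc(-c2nn(-c3ccccc3)cc2-c2nc3cc(C(F)(F)F)ccc3[nH]2)cc1` has not yet been measured. It differs from compound 3 by trifluoromethyl in place of methyl on an aromatic carbon, which is the same change that separates compound 1 from compound 2, at the same place on the core. Going by the values given here, the only guide to its effect is that single earlier step, so compound 4 is expected to show a similar gain, a step of a 2.2-fold lower number from compound 3 to compound 4 (0.34 log units; beyond the scatter) from compound 3, because the same change gave a 2.2-fold lower number from compound 1 to compound 2 (0.35 log units; beyond the scatter). Whether the two changes add up together is not known from these data, so the range is kept wide. The estimate for compound 4 in this assay is 510 nM, expected to fall between 200 nM and 1300 nM.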

Compound 4, half-maximal inhibitory concentration: 2130 nM
Compound 4: middle estimate off by 4.2-fold (0.62 log units), on the low side; the measured number lies above the stated range.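

In this assay, trifluoromethyl in place of methyl does not repeat its earlier gain on the core of compound 3: the new step, a 1.9-fold higher number from compound 3 to compound 4 (0.28 log units; within the scatter), leaves the two compounds level, and it differs from the earlier step: the same change on two cores in this assay, a 2.2-fold lower number (0.35 log units; beyond the scatter) from compound 1 to compound 2 and a 1.9-fold higher number (0.28 log units; within the scatter) from compound 3 to compound 4, 4.2-fold (0.63 log units) apart, beyond the scatter of two such steps. Seen from the other side, fluoro in place of hydrogen gave a clear gain on the methyl compounds but a 1.2-fold lower number from compound 2 to compound 4 (0.10 log units; within the scatter) on the trifluoromethyl compounds, so the two changes do not add up in these four compounds: the same change on two cores in this assay, a 5.3-fold lower number (0.72 log units; beyond the scatter) from compound 1 to compound 3 and a 1.2-fold lower number (0.10 log units; within the scatter) from compound 2 to compound 4, 4.2-fold (0.63 log units) apart, beyond the scatter of two such steps. This shows that, within this small set, the effect of each change depends on which group is present at the other place, but it does not show why, and one pair of steps per change cannot predict what either change will do on a further core.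

The compounds shown leave open whether a chlorine, a methoxy group or an amine in place of methyl would behave like trifluoromethyl. They also leave open whether a fluoro-bearing compound with plain hydrogen in that place would keep the gain.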